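Formyl at the chain end of compound 1

A few compounds are considered here, and "the series" means these few. Any claim that something is new, unique, unknown or untested is made for them only; others in the source may bear on it.

For the measured compounds named here, compound 1 `CCc1onc(NS(=O)(=O)c2ccc(C(C)(C)C)cc2)c1Sc1cccc(OC)c1` was tested in an assay on COS-7 cells for displacement of a labelled ligand from Endothelin receptor type B (Sus scrofa) (on this read-out lower numbers stand for stronger inhibition and higher numbers for weaker inhibition), and gave 2800 nM, the higher of the two numbers recorded, with compound 2 as its only neighbour. Compound 2 `COc1cccc(Sc2c(NS(=O)(=O)c3ccc(C(C)(C)C)cc3)noc2CCCC(=O)O)c1` gave 500 nM in this assay, which amounts to a 5.6-fold lower number from compound 1 to compound 2 (0.75 log units; beyond the scatter). The unmeasured compound 3 `COc1cccc(Sc2c(NS(=O)(=O)c3ccc(C(C)(C)C)cc3)noc2CCC=O)c1` differs from compound 1 at the same chain position: formyl in place of hydrogen on a saturated chain carbon, two bonds along the chain from an aromatic carbon. Going by the values given here, the single step that bears on it is the one from compound 1 to compound 2, where a carboxymethyl group entered at this place and the number fell by a modest but clear margin; the formyl group of compound 3 is smaller and brings an acceptor without a donor, so a smaller gain is expected. The expected step is a 2.3-fold lower number from compound 1 to compound 3 (0.37 log units; beyond the scatter), and compound 3 is estimated at 1200 nM in this assay, in a range from 400 nM to 3500 nM.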

Compound 3, half-maximal inhibitory concentration: 500 nM
For compound 3 the middle estimate is 2.4-fold (0.38 log units) above the measured one, within the range that was stated.
By their numbers in this assay, from the lowest: compounds 2 and 3 (each within the scatter of the next); then compound 1.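

In this assay, the gain at this chain position is no longer tied to carboxymethyl alone: formyl in place of hydrogen gives a 5.6-fold lower number from compound 1 to compound 3 (0.75 log units; beyond the scatter), so a second, smaller group also separates from the unsubstituted chain of compound 1. The two groups themselves cannot be told apart here, with no change at the digits printed from compound 2 to compound 3 (within the scatter), which means that this read-out draws no distinction between formyl and carboxymethyl at this place. Nothing available explains why the two groups read alike.

From the compounds shown here alone, whether the gain needs the carbonyl at all, or would also appear with a plain propyl or butyl chain, remains open. So does the outcome with a hydroxymethyl group, an amine or a longer chain ending in a carboxylic acid at this same place.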